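The source may hold more compounds than are shown below. What is called first, only, known or untested is meant among the compounds shown, and "the series" means these compounds.

Compound 3 `O=C(Nc1cccc(OCc2ccc(-c3ccccc3)cc2)c1)C1CCNCC1` was tested in a functional assay on a cell-free system (Platelet, plasma, Homo sapiens) for inhibition (on this read-out higher numbers stand for weaker inhibition and lower numbers for stronger inhibition), and gave 54000 nM. Its neighbour compound 1 `O=C(Nc1cccc(OCc2ccc(-c3ccccc3)cc2)c1)C1CCCNC1` gave 87000 nM in this assay, and the step of a 1.6-fold lower number from compound 1 to compound 3 (0.21 log units; within the scatter) is within the scatter, so the two compounds are not told apart. Compound 2 `N=C(N)N1CCCC(C(=O)Nc2cccc(OCc3ccc(-c4ccccc4)cc3)c2)C1` belongs to the same series; in this assay compound 2 has "not determined" (no result reported), that is, no result was reported for it. Among the numbers shown, compound 3 has the lowest, but only by a step that the scatter covers.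

Compound 4 `O=C(Nc1cccc(OCc2ccc(-c3cc(F)cc(F)c3)cc2)c1)C1CCNCC1` is the next compound. It differs from compound 3 in one place: 3,5-difluorophenyl in place of phenyl on an aromatic carbon. The group enters on an aromatic carbon of a six-membered aromatic ring of carbon only.

Among the measured compounds shown here, none of the measured steps concerns this kind of change. For the measured compounds named here, the only step measured so far, a 1.6-fold lower number from compound 1 to compound 3 (0.21 log units; within the scatter), moves the ring nitrogen within the saturated ring on the carbonyl carbon and says nothing about the aromatic ring at the far end. Going by the values given here, with no comparable step to lean on, the expectation is that the step from compound 3 to compound 4 stays within the scatter, in no particular direction, and so compound 4 is estimated at 45000 nM in this assay, with a range from 15000 nM to 140000 nM, corresponding to an expected step of a 1.2-fold lower number from compound 3 to compound 4 (0.08 log units; within the scatter).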

Compound 4, half-maximal inhibitory concentration: 17000 nM
Compound 4: the middle estimate sits 2.6-fold (0.42 log units) above what was measured; low and high end bracket the measured number.
By their numbers in this assay, from the lowest: compound 4; then compounds 3 and 1 (each within the scatter of the next).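

In this assay, among the compounds shown here, the replacement of phenyl by 3,5-difluorophenyl, on an aromatic carbon para to a large group, gives a 3.2-fold lower number from compound 3 to compound 4 (0.50 log units; beyond the scatter) and so marks stronger inhibition, by a modest step that is the first to lie beyond the scatter. For the compounds shown here, the earlier pair differed only in the saturated ring on the carbonyl carbon and could not be told apart, so this aromatic position is the first place where a change in structure is seen to move the number. Nothing in the data shown explains why this replacement lowers the number.

The compounds shown leave open whether both fluorine atoms are needed, since a phenyl carrying a single fluorine, or one carrying chlorine atoms or methoxy groups in their place, does not appear among them. Going by these compounds alone, they also leave open whether the same 3,5-difluorophenyl replacement would give a comparable step on the piperidin-3-yl compound 1, as the one step available here was read on the piperidin-4-yl compound 3 alone.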